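The compounds below may be only part of what the source reports. "The series", "measured", "known", "first", "only" and "open" are said of these compounds alone.

Compound 1 `Cc1ccccc1OS(=O)(=O)c1ccc(NC(=O)NCCCCl)cc1` and compound 2 `CCc1ccccc1OS(=O)(=O)c1ccc(NC(=O)NCCCCl)cc1` share one core and differ in a single small change, (methyl in place of hydrogen on a saturated chain carbon bound to an aromatic carbon). In a functional assay on HT-29 cells (Homo sapiens) for cytotoxicity, read by sulforhodamine B assay, with a stated time of 48 h (on this read-out higher numbers stand for weaker inhibition and lower numbers for stronger inhibition), compound 1 gives 26000 nM, and compound 2 gives 15000 nM; the step is a 1.7-fold lower number from compound 1 to compound 2 (0.24 log units; within the scatter). Compound 3 `CCc1ccccc1NS(=O)(=O)c1ccc(NC(=O)NCCCCl)cc1` rests on a different core; the difference between the two cores is not broken down here. In this assay compound 3 reaches only a limit, > 200000 nM. Compound 4 `CCCc1ccccc1NS(=O)(=O)c1ccc(NC(=O)NCCCCl)cc1` comes from compound 3 by the same kind of change, (methyl in place of hydrogen on a saturated chain carbon, two bonds along the chain from an aromatic carbon), though the place is not the same: the carbon is two bonds along the chain from an aromatic carbon rather than bound to one. A step that the limit leaves unreadable from compound 3 to compound 4 is expected, resting on a 1.7-fold lower number from compound 1 to compound 2 (0.24 log units; within the scatter) and on (the limit of > 200000 nM in this assay, at which 1 of the 3 values shown sits). Compound 4 is therefore estimated at 250000 nM, most likely again as a limit rather than a number.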

Compound 4, half-maximal inhibitory concentration: 26000 nM
Compound 4: the middle estimate sits 9.6-fold (0.98 log units) above what was measured, outside the stated range (below it).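

Compound 3 reads > 200000 nM, which is a limit and not a number. Adding the methyl in this assay gives an at least 7.6-fold lower number from compound 3 to compound 4 (0.88 log units; beyond the scatter), so the size of this change does not carry over unchanged from one core to the other: the same change on two cores in this assay, a 1.7-fold lower number (0.24 log units; within the scatter) from compound 1 to compound 2 and an at least 7.6-fold lower number (0.88 log units; beyond the scatter) from compound 3 to compound 4, at least 4.4-fold (0.64 log units) apart, beyond the scatter of two such steps The two pairs also differ in where the methyl sits on the chain, so these compounds cannot separate the effect of the core from that of the place, and they do not give the true size of the step from compound 3 to compound 4.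

Going by these compounds, it stays open whether a longer chain, such as butyl, would lower the number again on the core of compound 4. On these data alone, it also stays open how a propyl group would behave on the core of compound 1.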